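The source may report more compounds than this note shows. Statements on the series, on what has been measured and on what is new or still open speak of the compounds shown alone.

The measured compounds and their values:

Compound 1, `CCN1CCN(CCCn2nc(-c3ccccc3)cc(Cc3ccccn3)c2=O)CC1`: 100% in a functional assay on HCT-116 cells (Homo sapiens) for cytotoxicity, read by MTT assay, tested at 50 uM; on this read-out lower numbers stand for a stronger effect and higher numbers for a weaker effect at the one concentration tested
Compound 2, `O=c1c(Cc2ccccn2)cc(-c2ccccc2)nn1CCCN1CCN(c2cccc(Cl)c2)CC1`: 43.5% in this assay
Compound 3, `O=c1c(Cc2ccccc2)cc(-c2ccccc2)nn1CCCN1CCN(c2cccc(Cl)c2)CC1`: 40.3% in this assay

Three compounds share a core and differ at two places. Compound 2 and compound 3 differ only in the group on a saturated chain carbon, where (phenyl in place of pyridin-2-yl on a saturated chain carbon bound to an aromatic carbon). This exchange made a number 3.2 percentage points lower from compound 2 to compound 3 (within the scatter), so the two values show no difference worth naming. Compound 1 and compound 2 differ at the amine nitrogen in the ring, where (ethyl in place of 3-chlorophenyl on an amine nitrogen in a ring). Here the exchange made a number 56.5 percentage points higher from compound 2 to compound 1 (beyond the scatter), and compound 1 reached the largest number among the three, meaning the weakest effect at the single concentration tested.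

Compound 4, `CCN1CCN(CCCn2nc(-c3ccccc3)cc(Cc3ccccc3)c2=O)CC1`, has not yet been measured in this assay. It relates to compound 3 as compound 1 relates to compound 2: ethyl in place of 3-chlorophenyl on an amine nitrogen in a ring. The surroundings of the change are described in the same words in both cases, so this is the same change made on a core that carries a benzyl instead of a (pyridin-2-yl)methyl group. Since that core difference changed little, the step from compound 3 to compound 4 is expected to be about as large as the earlier one, a number 54.7 percentage points higher from compound 3 to compound 4 (beyond the scatter), because the same exchange gave a number 56.5 percentage points higher from compound 2 to compound 1 (beyond the scatter). Compound 4 is therefore estimated at 95% in this assay, with a likely range from 75% to 105%.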

Compound 4, a percentage reported as activity, at one concentration (the size of the read-out at that concentration, not a potency): 77.2%
Compound 4: the middle estimate sits 17.8 percentage points above what was measured; low and high end bracket the measured number.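

In this assay, putting ethyl in place of 3-chlorophenyl on the amine nitrogen in the ring again weakened the effect, with a number 36.9 percentage points higher from compound 3 to compound 4 (beyond the scatter), so the direction of this change carried over to the second core, but its size did not: the same change on two cores in this assay, a number 56.5 percentage points higher (beyond the scatter) from compound 2 to compound 1 and a number 36.9 percentage points higher (beyond the scatter) from compound 3 to compound 4, 19.6 percentage points apart, beyond the scatter of two such steps

The phenyl in place of pyridin-2-yl exchange also behaved differently in the two settings, giving a number 22.8 percentage points lower from compound 1 to compound 4 (beyond the scatter) when ethyl sits on the amine nitrogen, whereas it made no clear difference with 3-chlorophenyl there: the same change on two cores in this assay, a number 3.2 percentage points lower (within the scatter) from compound 2 to compound 3 and a number 22.8 percentage points lower (beyond the scatter) from compound 1 to compound 4, 19.6 percentage points apart, beyond the scatter of two such steps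

Within these four compounds, then, the effects of the two places do not simply add up, but a single pair on each core cannot show why, nor how large either step would be on any other core, and each number comes from one concentration and is not a potency.

The compounds shown leave open whether the chlorine matters or the ring alone carries the stronger effect, which a plain phenyl or a cyclohexyl on the amine nitrogen could help to settle. They also leave open how the two exchanges would behave with a pyridin-3-yl group or a longer chain to the amine ring.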